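Nitro analogue of phenyl-indole core: expectation before measurement

The source may hold more compounds than are shown below. What is called first, only, known or untested is meant among the compounds shown, and "the series" means these compounds.

Compound 2 `O=[N+]([O-])c1ccc2[nH]c(-c3cccnc3)cc2c1` stands lowest of the three numbers in hand. In an assay on isolated protein for inhibition of Aromatase (Homo sapiens), read by fluorescence, using NADPH, with a stated time of 30 min, tested at 50 uM (a lower number here means less inhibition, a higher number more inhibition at the concentration tested (going by the name of the read-out)), compound 2 gives 27.9%. Its nearest neighbour is compound 1 `N#Cc1ccc2[nH]c(-c3ccccc3)cc2c1`, which in this assay gives 82.3%, and the furthest is compound 3 `N#Cc1ccc2[nH]c(-c3cccnc3)cc2c1`, which in this assay gives 93.7%. Among the measured compounds shown here, the only measured step, a number 65.8 percentage points higher from compound 2 to compound 3 (beyond the scatter), changes the substituent on the benzene side of the shared core and does not touch the change now at hand. The step to compound 4 `O=[N+]([O-])c1ccc2[nH]c(-c3ccccc3)cc2c1` is phenyl in place of pyridin-3-yl on an aromatic carbon. The same change, between compound 3 and compound 1, is not reported as a step; their two values in this assay simply show what was stated above, a modest difference on a cyano background. For the measured compounds named here, no step with nitro present bears on the change. On that basis the expected step in this assay is a number 7.9 percentage points lower from compound 2 to compound 4 (within the scatter), small and likely downward, not clearly beyond the scatter. Compound 4 is therefore estimated at 20% in this assay, within a range from 5% to 40%.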

Compound 4, a percentage reported as inhibition, at one concentration (the size of the read-out at that concentration, not a potency): 77.7%
The estimate for compound 4 lay 57.7 percentage points below the measured number, and the stated range ends below it.
By their numbers in this assay, from the lowest: compound 2; then compounds 4 and 1 (each within the scatter of the next); then compound 3.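

In this assay, phenyl in place of pyridin-3-yl on an aromatic carbon next to the ring nitrogen gives a number 49.8 percentage points higher from compound 2 to compound 4 (beyond the scatter), so on the nitro background this position carries a large change. With phenyl at that position, nitro in place of cyano gives a number 4.6 percentage points lower from compound 1 to compound 4 (within the scatter), so the low number of compound 2 belongs to nitro and pyridin-3-yl together, not to nitro alone. The effect of exchanging nitro for cyano therefore depends on the group at this position: the same change on two cores in this assay, a number 65.8 percentage points higher (beyond the scatter) from compound 2 to compound 3 and a number 4.6 percentage points higher (within the scatter) from compound 4 to compound 1, 61.2 percentage points apart, beyond the scatter of two such steps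

Going by these compounds, whether this dependence extends to other groups remains open, for example an amine or a carboxylic acid in place of nitro or cyano. All numbers are readings at one concentration, so they leave the potencies of these compounds open.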